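This account rests on a few compounds, and the source may have more. Where it says the series, first, only, none or still open, it means among the compounds named here.

Going by the values given here, in a functional assay on the whole organism for antagonist activity, with Mus musculus as the target (a higher number here means that more compound is needed for the effect, a lower number that less compound is needed), compound 1 `CCC(=O)N(c1ccc(Cl)c(Cl)c1)C1CCCC1O` gives 9 mg/kg and compound 2 `C=CCN(C)C1CCCC1N(C(=O)CC)c1ccc(Cl)c(Cl)c1` gives 0.2 mg/kg, the lower of the only two numbers so far. Among the compounds with values here, the one measured step, a 45-fold lower number from compound 1 to compound 2 (1.65 log units; beyond the scatter), puts allyl(methyl)amino in place of hydroxy on a saturated ring carbon. That large step shows that a change at this place can matter, but it does not test the next change. Compound 3 `CCC(=O)N(c1ccc(Cl)c(Cl)c1)C1CCCC1N(C)CCCN(C)C` differs from compound 2 in one chain: 2-(dimethylamino)ethyl in place of vinyl on a saturated chain carbon bound to an amine nitrogen. Here, 2-(dimethylamino)ethyl stands in place of vinyl on a saturated chain carbon bound to an amine nitrogen, turning allyl into 3-(dimethylamino)propyl. With compound 2 at 0.2 mg/kg, the lowest number seen, a moderate rise is expected in this assay, although a result within the scatter remains possible. The expected step is a 4.0-fold higher number from compound 2 to compound 3 (0.60 log units; beyond the scatter). For compound 3 the estimated value is 0.8 mg/kg, with a range from 0.15 mg/kg to 5 mg/kg.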

Compound 3, dose for half-maximal effect: 10 mg/kg
Compound 3: middle estimate off by 13-fold (1.10 log units), on the low side; measured number above the stated range.
By their numbers in this assay, from the lowest: compound 2; then compounds 1 and 3 (each within the scatter of the next).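

In this assay the step of a 50-fold higher number from compound 2 to compound 3 (1.70 log units; beyond the scatter) shows that the amine on this saturated ring carbon does not give a low number whatever chain it carries: the outer part of the chain counts as well. The step of a 1.1-fold higher number from compound 1 to compound 3 (0.05 log units; within the scatter) lies within the scatter, so (3-(dimethylamino)propyl)(methyl)amino offers no measurable gain over hydroxy, unlike the allyl(methyl)amino group in the step of a 45-fold lower number from compound 1 to compound 2 (1.65 log units; beyond the scatter) on the same carbon. Nothing available explains this large difference between the two chains.

The compounds shown leave open whether the loss follows from the terminal dimethylamino group, the longer chain or the missing double bond. A plain propyl or butyl chain on the same nitrogen would help separate these three changes.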